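Halogen exchange on two cores of a thiosemicarbazone series

This account rests on a few compounds, and the source may have more. Where it says the series, first, only, none or still open, it means among the compounds named here.

Two cores carry the same pair of halogens here. Compound 1 `NC(=S)N/N=C1/C(=O)N(CN2CCN(c3ccnc4cc(C(F)(F)F)ccc34)CC2)c2cccc(Cl)c21` and compound 2 `NC(=S)N/N=C1/C(=O)N(CN2CCN(c3ccnc4cc(C(F)(F)F)ccc34)CC2)c2cccc(Br)c21` share the larger core; compound 3 `NC(=S)N/N=C1\C(=O)Nc2cccc(Cl)c21` and compound 4 `NC(=S)N/N=C1\C(=O)Nc2cccc(Br)c21` share the smaller one. The difference between the two cores is not broken down here.

In a functional assay on MCF7 cells (Homo sapiens) for cytotoxicity, read by sulforhodamine B assay, with a stated time of 48 h (on this read-out lower numbers stand for stronger inhibition of growth and higher numbers for weaker inhibition of growth), compound 1 gives 21600 nM. Within the data shown here, compound 2, which differs by bromo in place of chloro on an aromatic carbon, gives 50600 nM in this assay; the step of a 2.3-fold higher number from compound 1 to compound 2 (0.37 log units; beyond the scatter) is the one measured example of this change. Compound 3 gives 30200 nM in this assay, close to compound 1 and to compound 2 within the usual scatter, so no order among these three is claimed.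

Compound 4 is not yet measured in this assay. It differs from compound 3 by bromo in place of chloro on an aromatic carbon, the same change as from compound 1 to compound 2, at the same place as far as the structures tell. With a single precedent, the expectation rests only on compound 1 and compound 2: a shift of the same sign and roughly the same size. One example carries little weight. The expected shift is softened a little. The expected step is a 1.8-fold higher number from compound 3 to compound 4 (0.26 log units; within the scatter). Compound 4 is therefore estimated at 55000 nM in this assay, with a plausible range from 25000 nM to 130000 nM.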

Compound 4, concentration for 50% growth inhibition: 14800 nM
The estimate for compound 4 lay 3.7-fold (0.57 log units) above the measured number, and the stated range ends above it.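

In this assay, among these compounds, bromo in place of chloro on an aromatic carbon gives a 2.0-fold lower number from compound 3 to compound 4 (0.31 log units; beyond the scatter), so on the core of compound 3 the change runs in the opposite direction to its one earlier example on the core of compound 1. Among the compounds shown here, the same exchange therefore does not carry over from one core to the other as a shift of fixed direction: the same change on two cores in this assay, a 2.3-fold higher number (0.37 log units; beyond the scatter) from compound 1 to compound 2 and a 2.0-fold lower number (0.31 log units; beyond the scatter) from compound 3 to compound 4, 4.8-fold (0.68 log units) apart, beyond the scatter of two such steps This shows that, across these two pairs, the outcome of the halogen exchange depends on the core, but with only one pair per core it does not show which structural difference between the cores matters, nor does it give a rule for any further core.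

The compounds shown leave open how fluoro, iodo, methyl or methoxy at the same place would read on each core, and whether any of these would follow the order of compound 1 and compound 2 or that of compound 3 and compound 4. They also leave open whether a core carrying only part of what separates the core of compound 1 from that of compound 3 would show the step in one direction or the other.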